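A few compounds are considered here, and "the series" means these few. Any claim that something is new, unique, unknown or untested is made for them only; others in the source may bear on it.

Measured compounds in an assay on cells for inhibition of Rho-associated protein kinase 2 (Homo sapiens), read by radiometric assay and 33P incorporation, in the presence of a further agent that is not named here; on this read-out higher numbers stand for weaker inhibition and lower numbers for stronger inhibition:
- Compound 1 `CCCOC(=O)c1ccc(NC(=O)c2cccc(-c3cc(C(=O)Nc4ccncc4F)ccc3CN)c2)cc1` gives < 1 nM; this value is a limit of the assay.
- Compound 2 `NCc1ccc(C(=O)Nc2ccncc2F)cc1-c1cccc(C(=O)Nc2ccc(CC(=O)O)cc2)c1` gives 1.8 nM.
- Compound 3 `NCc1ccc(C(=O)Nc2ccncc2F)cc1-c1cccc(C(=O)Nc2ccccc2)c1` gives < 1 nM; this value is a limit of the assay.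

Compound 3 therefore stands at the floor of what this assay reports, and the same holds for compound 1, as the limit of < 1 nM in this assay, at which 2 of the 3 values shown sit, shows. Only compound 2 returns a number. Compound 4 `NCc1ccc(C(=O)Nc2ccncc2F)cc1-c1cccc(C(=O)Nc2cccc(C(=O)O)c2F)c1` differs from compound 3 by 3-carboxy-2-fluorophenyl in place of phenyl on an amide-type nitrogen. Going by the values given here, two measured steps bear on this change. The step of an at least 1.8-fold lower number from compound 2 to compound 3 (0.25 log units; that floor lies within the scatter) removed a carboxymethyl group and moved the value onto the limit. The step of an at least 1.8-fold higher number from compound 1 to compound 2 (0.25 log units; that floor lies within the scatter) replaced propoxycarbonyl by carboxymethyl and lifted the value off the limit. Both floors lie within the scatter, and a step that the two limits leave unreadable from compound 1 to compound 3 cannot be read at all. Introducing a 3-carboxy-2-fluorophenyl group onto the amide nitrogen of compound 3 is thus expected to give a step of an at least 1.5-fold higher number from compound 3 to compound 4 (0.17 log units; that floor lies within the scatter) in this assay that is small and may keep compound 4 near the limit. The estimate for compound 4 in this assay is 1.5 nM, within a range of 0.5 nM to 5 nM.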

Compound 4, half-maximal inhibitory concentration: 3.5 nM
The estimate for compound 4 lay 2.3-fold (0.37 log units) below the measured number, within the range that was stated.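

In this assay, 3-carboxy-2-fluorophenyl in place of phenyl on the amide-type nitrogen gave an at least 3.5-fold higher number from compound 3 to compound 4 (0.54 log units; beyond the scatter), and in place of 4-(propoxycarbonyl)phenyl it gave an at least 3.5-fold higher number from compound 1 to compound 4 (0.54 log units; beyond the scatter), so changes at this nitrogen now reach beyond the scatter, which no readable earlier step did. Compound 1 and compound 3 each sit at a limit of the assay, so these two steps are floors and their full size cannot be read: the limit of < 1 nM in this assay, at which 2 of the 4 values shown sit. Set against 4-(carboxymethyl)phenyl, the same group gave a 1.9-fold higher number from compound 2 to compound 4 (0.29 log units; within the scatter), so the two groups carrying a carboxylic acid are not told apart here, and compound 2 and compound 4 are the only two of the series that return a number rather than a limit.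

Whether the carboxylic acid or the fluorine carries the step from phenyl stays open, as a fluorophenyl group without the acid and a carboxyphenyl group without the fluorine are not among the compounds shown. Also open, going by these compounds, is how this position would read with an amine or a propyl ester in place of the carboxylic acid of the 3-carboxy-2-fluorophenyl group.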